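The compounds below may be only part of what the source reports. "The series", "measured", "known", "first", "only" and "open" are said of these compounds alone.

Among the measured compounds shown here, compound 1, `COc1cc(CNc2nc3cc(N)cc(N)c3nc2-c2ccccc2)cc(OC)c1OC`, is the only member of this small set to return a number in a functional assay on HOP-92 cells (Homo sapiens) for inhibition, read by sulforhodamine B assay, with a stated time of 48 h; on this read-out lower numbers stand for stronger inhibition of growth and higher numbers for weaker inhibition of growth: there compound 1 gives 3090 nM. Compound 2, `CCOC(=O)[C@H](CCC(=O)O)NC(=O)c1ccc(Oc2nc3cc(N)cc(N)c3nc2-c2ccccc2)cc1`, stands apart in that it gives only a limit of the assay, < 100000 nM, in this assay; the data show (the limit of < 100000 nM in this assay, at which 1 of the 2 values shown sits), and nothing more can be said of where compound 2 sits. Compound 1 therefore marks the sole fixed point against which the next compound is weighed.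

Compound 3, `COc1ccc(CNc2nc3cc(N)cc(N)c3nc2-c2ccccc2)cc1OC`, shares the core of compound 1 and differs from it in a single place: hydrogen in place of methoxy on an aromatic carbon. For the measured compounds named here, no measured pair in this set differs in just one place, so the size of this step has no precedent here. The change is small in what it removes, and compound 3 is expected to sit close to compound 1, with a step from compound 1 to compound 3 of a 1.3-fold higher number from compound 1 to compound 3 (0.11 log units; within the scatter), which is expected to fall within or only slightly beyond the usual scatter. In this assay compound 3 is estimated at 4000 nM, with the expectation that a measurement would fall between 1500 nM and 12000 nM.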

Compound 3, concentration for total growth inhibition: 29500 nM
Beside the measured number, compound 3's estimate is 7.4-fold (0.87 log units) below it; the measured number lies above the stated range.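

Hydrogen in place of methoxy on an aromatic carbon gives a 9.5-fold higher number from compound 1 to compound 3 (0.98 log units; beyond the scatter) in this assay, the first step in this set that can be read, and it lies beyond the scatter. On this read-out a higher number stands for weaker inhibition of growth, so within this pair the methoxy group at this place, ortho to a methoxy group and meta to a large group, counts towards the inhibition that compound 1 shows, and the change cannot be treated as a minor trim of the molecule. Nothing in the data shown accounts for the size of this step.

Going by these compounds, only methoxy and hydrogen are compared at this place, so it stays open whether a hydroxyl, an ethoxy or a fluorine there would keep the number near that of compound 1 or move it towards that of compound 3. On these data alone, it also stays open whether taking away either of the other methoxy groups of compound 1 would give a step of similar size, since this single pair speaks for one place only.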